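The source may report more compounds than this note shows. Statements on the series, on what has been measured and on what is new or still open speak of the compounds shown alone.

Three compounds built on a shared core were examined in a functional assay on HL-60 cells (Homo sapiens) for inhibition, read by CCK-8 assay, with a stated time of 48 h; a higher number here means a weaker inhibitor, a lower number a stronger inhibitor. Compound 1 `O=C(NCCNS(=O)(=O)c1sccc1-c1ccccc1Oc1ccc(O)c(O)c1)Nc1cc(Cl)cc(Cl)c1` gives 6900 nM. Compound 2 `CC(C)c1ccc(Oc2ccc(O)c(O)c2)c(-c2ccsc2S(=O)(=O)NCCNC(=O)Nc2cc(Cl)cc(Cl)c2)c1`, the isopropyl-bearing analogue, gives 6500 nM. Compound 3 `CC(C)c1ccc(Oc2ccc(O)c(O)c2)c(-c2ccsc2S(=O)(=O)NCCNC(=S)Nc2cc(C(F)(F)F)cc(C(F)(F)F)c2)c1`, a thiourea carrying two trifluoromethyl groups, gives 8200 nM. All three numbers sit close together, and none of the gaps among them is larger than the usual scatter of this measurement.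

Compound 2 and compound 1 differ in one place only: hydrogen in place of isopropyl on an aromatic carbon. That change produced a 1.1-fold higher number from compound 2 to compound 1 (0.03 log units; within the scatter). How the core of compound 3 differs from that of compound 2 is not broken down here, and the two values simply show that compound 3 and compound 2 lie within the scatter of each other.

Compound 4 `O=S(=O)(NCCNC(=S)Nc1cc(C(F)(F)F)cc(C(F)(F)F)c1)c1sccc1-c1ccccc1Oc1ccc(O)c(O)c1` is the unmeasured member of the set. It stands to compound 3 exactly as compound 1 stands to compound 2, the change being (hydrogen in place of isopropyl on an aromatic carbon), the same change at the same place. The earlier instance of this change gave a 1.1-fold higher number from compound 2 to compound 1 (0.03 log units; within the scatter). On that basis compound 4 is expected to show a 1.0-fold higher number from compound 3 to compound 4 (0.02 log units; within the scatter). Compound 4 is therefore estimated at 8500 nM, most likely between 4500 nM and 16000 nM.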

Compound 4, half-maximal inhibitory concentration: 4300 nM
For compound 4 the middle estimate is 2.0-fold (0.30 log units) above the measured one, and the stated range ends above it.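

In this assay, hydrogen in place of isopropyl on the core of compound 3 gave a 1.9-fold lower number from compound 3 to compound 4 (0.28 log units; within the scatter). Set beside the earlier instance of the same change, this step does not differ from it beyond the scatter: the same change on two cores in this assay, a 1.1-fold higher number (0.03 log units; within the scatter) from compound 2 to compound 1 and a 1.9-fold lower number (0.28 log units; within the scatter) from compound 3 to compound 4, 2.0-fold (0.31 log units) apart, within the scatter of two such steps. Among the compounds shown here, the two pairs therefore give no sign that the core alters what this change does, and neither step shows a real effect of removing isopropyl; but with only two pairs, each with a step inside the scatter, they do not establish that the change would carry unaltered to any other core.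

The compounds shown leave open how a methyl, a tert-butyl, a methoxy group or an amine would read at this same place on the aromatic ring, where only hydrogen and isopropyl appear here. They also leave open whether a larger step would appear if the 3,4-dihydroxyphenoxy group were exchanged for a methoxy-bearing phenoxy group or the ethylene chain for a longer chain.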